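Carbamate in Place of Methyl on the Ring Nitrogen

This account rests on a few compounds, and the source may have more. Where it says the series, first, only, none or still open, it means among the compounds named here.

Compound 1, `CN1CCc2c(sc(NC(=O)c3ccc(Cl)cc3)c2C(N)=O)C1`, gives 38.5% in an ADME assay on RAW264.7 cells (Mus musculus) for cytotoxicity, read by MTT assay, with a stated time of 48 h, tested at 50 uM; a lower number here means less inhibition, a higher number more inhibition at the concentration tested (going by the name of the read-out). Compound 2, `CC(C)(C)OC(=O)N1CCc2c(sc(NC(=O)c3ccc(Cl)cc3)c2C(N)=O)C1`, gives 37.3% in this assay. Compound 3, `CN1CCc2c(sc(NC(=O)c3ccc(Oc4ccccc4)cc3)c2C(N)=O)C1`, gives 58.9% in this assay.

Of the compounds shown here, three share a core and have been measured. The change from compound 1 to compound 2 is tert-butoxycarbonyl in place of methyl on an amine nitrogen in a ring; it gave a number 1.2 percentage points lower from compound 1 to compound 2 (within the scatter). The two cores of compound 1 and compound 3 differ by phenoxy in place of chloro on an aromatic carbon, which gave a number 20.4 percentage points higher from compound 1 to compound 3 (beyond the scatter). Compound 3 stands highest of the three, and its steps to compound 1 and to compound 2 lie beyond the scatter.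

Compound 4, `CC(C)(C)OC(=O)N1CCc2c(sc(NC(=O)c3ccc(Oc4ccccc4)cc3)c2C(N)=O)C1`, has not yet been measured. It differs from compound 3 by tert-butoxycarbonyl in place of methyl on an amine nitrogen in a ring, the same change that compound 2 shows against compound 1, made on the core of compound 3. Because that change gave a number 1.2 percentage points lower from compound 1 to compound 2 (within the scatter), compound 4 is expected to sit close to compound 3, with an expected step of a number 1.4 percentage points lower from compound 3 to compound 4 (within the scatter) in this assay. The estimate for compound 4 is therefore 57.5%, ranging from 45% to 70%.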

Compound 4, a percentage reported as inhibition, at one concentration (the size of the read-out at that concentration, not a potency): 26.9%
For compound 4 the middle estimate is 30.6 percentage points above the measured one; the whole stated range lies above it.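

On the core of compound 3, the tert-butoxycarbonyl change gave a number 32 percentage points lower from compound 3 to compound 4 (beyond the scatter) in this assay, so the near absence of a step on the core of compound 1 did not carry over: the same change on two cores in this assay, a number 1.2 percentage points lower (within the scatter) from compound 1 to compound 2 and a number 32 percentage points lower (beyond the scatter) from compound 3 to compound 4, 30.8 percentage points apart, beyond the scatter of two such steps. Phenoxy in place of chloro gave a number 10.4 percentage points lower from compound 2 to compound 4 (beyond the scatter), so the outcome of that change also differed with the core, reversing in direction once tert-butoxycarbonyl stood on the amine nitrogen: the same change on two cores in this assay, a number 20.4 percentage points higher (beyond the scatter) from compound 1 to compound 3 and a number 10.4 percentage points lower (beyond the scatter) from compound 2 to compound 4, 30.8 percentage points apart, beyond the scatter of two such steps. These four compounds show that neither change can be treated as a fixed increment here, but they do not show why the two changes interact or whether this holds for any other core, and the read-out at a single concentration is not a potency.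

From the compounds shown here alone, it remains open whether the same interaction would appear with another group on that nitrogen, such as acetyl or benzyl. Going by these compounds, it is equally open whether another group in place of chloro, such as methoxy or phenyl, would behave as phenoxy does.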